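The source may report more compounds than this note shows. Statements on the series, on what has been measured and on what is new or still open speak of the compounds shown alone.

Measured so far:
compound 1 `O=C1C(NC2CCCC2)=CC(=O)c2c1nc1n2[C@H]2OC[C@@H](O)[C@H]2OC1` — > 16000 nM
compound 2 `O=C1C=C(Nc2ccc(Br)cc2)C(=O)c2c1nc1n2[C@H]2OC[C@@H](O)[C@H]2OC1` — 1010 nM
compound 3 `O=C1C=C(Nc2ccc(C(F)(F)F)cc2)C(=O)c2c1nc1n2[C@H]2OC[C@@H](O)[C@H]2OC1` — 2820 nM

In a functional assay on MGC-803 cells (Homo sapiens) for inhibition, read by sulforhodamine B assay (a higher number here means a weaker inhibitor, a lower number a stronger inhibitor), compound 1 gives > 16000 nM, and this is a limit of the assay rather than a number. Compound 2 and compound 3 carry an arylamino group on the shared core in place of the cyclopentylamino group of compound 1, and both give numbers: in this assay compound 2 gives 1010 nM and compound 3 gives 2820 nM. Among the compounds with values here, the one step measured between them, a 2.8-fold higher number from compound 2 to compound 3 (0.45 log units; beyond the scatter), is modest in size and concerns only the substituent on the aromatic ring.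

Compound 4 `O=C1C(NCc2ccccc2)=CC(=O)c2c1nc1n2[C@H]2OC[C@@H](O)[C@H]2OC1` has not yet been measured. It differs from compound 1 in one place: benzyl in place of cyclopentyl on an amine nitrogen. Within the data shown here, no measured step covers this change. The evidence from compound 2 and compound 3 shows that the compounds with an aromatic ring on that nitrogen fall within the measurable range, whereas compound 1 sits at the limit (the limit of > 16000 nM in this assay, at which 1 of the 3 values shown sits). Benzyl places an aromatic ring one carbon further from the nitrogen than in compound 2 and compound 3, so the number expected for compound 4 lies between the limit of compound 1 and the values of compound 2 and compound 3. Compound 4 is therefore expected to give about 8000 nM in this assay, within a range of 2500 nM to 20000 nM, corresponding to an expected step of an at least 2.0-fold lower number from compound 1 to compound 4 (0.30 log units; that floor lies within the scatter).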

Compound 4, half-maximal inhibitory concentration: 3490 nM
Compound 4: middle estimate off by 2.3-fold (0.36 log units), on the high side; measured number inside the range.
By their numbers in this assay, from the lowest: compound 2; then compounds 3 and 4 (each within the scatter of the next). At a limit, above all of these: compound 1.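

On the core of compound 1, the amine nitrogen offered only a limit until now: in this assay compound 1 gives > 16000 nM, which is a limit of the assay and not a number. Benzyl in place of cyclopentyl on that nitrogen now gives a step that can be read, an at least 4.5-fold lower number from compound 1 to compound 4 (0.66 log units; beyond the scatter), showing that on this core one change at this nitrogen is enough to bring a compound into the measurable range. That step is a floor and not a full size, as its starting point is a limit: the limit of > 16000 nM in this assay, at which 1 of the 4 values shown sits.

The change swaps a five-membered non-aromatic ring for a six-membered aromatic ring and adds a carbon between ring and nitrogen, so the compounds shown leave open which of these matters; a cyclohexylmethyl group on the same nitrogen would separate the ring type from the added carbon. Also open, from the compounds shown here alone, is whether bromo or trifluoromethyl on the benzyl ring would shift the number as it stands in this assay, since compound 4 differs from compound 2 and compound 3 in more than one place.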